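This account rests on a few compounds, and the source may have more. Where it says the series, first, only, none or still open, it means among the compounds named here.

Measured compounds:
compound 1 `COc1ccc(C(=O)/C=C/c2cc3ccccc3[nH]c2=O)cc1`: 2310 nM
compound 2 `O=C(/C=C/c1cc2ccccc2[nH]c1=O)c1ccc(O)cc1`: 1940 nM

In a functional assay on HCT-116 cells (Homo sapiens) for cytotoxicity, read by sulforhodamine B assay, with a stated time of 24 h (on this read-out lower numbers stand for stronger inhibition of growth and higher numbers for weaker inhibition of growth), compound 2 gives 1940 nM, and compound 1 gives 2310 nM. The two sit within the scatter of each other: the step of a 1.2-fold lower number from compound 1 to compound 2 (0.08 log units; within the scatter) is all that separates them, so neither can be set apart from the other on this read-out.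

Compound 3 `O=C(/C=C/c1cc2ccccc2[nH]c1=O)c1ccc(Cl)cc1` has not yet been measured in this assay. Its change from compound 2 is chloro in place of hydroxy on an aromatic carbon. For the measured compounds named here, the only measured step that touches the same six-membered aromatic ring of carbon only is a 1.2-fold lower number from compound 1 to compound 2 (0.08 log units; within the scatter), which swapped the group on the oxygen at that carbon and stayed within the scatter. Going by the values given here, no measured pair shows a chloro entering or a hydroxy leaving, so nothing in the two numbers points to a step beyond the scatter in either direction.

Compound 3 is therefore expected to land close to compound 2, with an estimated step of a 1.0-fold higher number from compound 2 to compound 3 (0.01 log units; within the scatter). The estimate for compound 3 in this assay is 2000 nM, with a range from 700 nM to 6000 nM.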

Compound 3, concentration for 50% growth inhibition: 3260 nM
Beside the measured number, compound 3's estimate is 1.6-fold (0.21 log units) below it; low and high end bracket the measured number.
By their numbers in this assay, from the lowest: compounds 2, 1 and 3 (each within the scatter of the next).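

In this assay, the step of a 1.7-fold higher number from compound 2 to compound 3 (0.23 log units; within the scatter) and the step of a 1.4-fold higher number from compound 1 to compound 3 (0.15 log units; within the scatter) both stay within the scatter, so this aromatic carbon, para to a large group, now has three substituents that cannot be set apart on this read-out. The earlier pair changed only the group on the oxygen, whereas these steps replace the oxygen-linked group itself with chloro, and the 4-hydroxyphenyl to 4-chlorophenyl change swaps a group counted with a hydrogen-bond donor and acceptor for one counted with neither, without a step beyond the scatter. Nothing measured here explains why these numbers stay so close.

The compounds shown leave open whether an amine or a carboxylic acid on this aromatic carbon, or a longer chain on the oxygen, would give a step beyond the scatter. They also leave open whether any change to the shared core would move the number further than these changes on the six-membered aromatic ring of carbon only have done.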